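A Chloro for a Nitro in a Flat Series

The source may report more compounds than this note shows. Statements on the series, on what has been measured and on what is new or still open speak of the compounds shown alone.

Of the compounds shown here, three sharing one core have been measured in a functional assay on HeLa cells (Homo sapiens) for antiproliferative activity, read by MTT assay, with a stated time of 48 h; on this read-out lower numbers stand for stronger inhibition and higher numbers for weaker inhibition. Compound 1 `Fc1ccccc1CSc1nnc(-c2ccc3c(c2)OCCO3)o1` gives 41600 nM, compound 2 `O=[N+]([O-])c1ccccc1CSc1nnc(-c2ccc3c(c2)OCCO3)o1` gives 32700 nM, and compound 3 `Cc1ccc(CSc2nnc(-c3ccc4c(c3)OCCO4)o2)cc1` gives 45400 nM. These numbers all lie within the usual scatter of one another, so compound 2 stands together with the other two rather than apart from them.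

Compound 4 `Clc1ccccc1CSc1nnc(-c2ccc3c(c2)OCCO3)o1` has not yet been measured. It differs from compound 2 in one group: chloro in place of nitro on an aromatic carbon. In short, this is chloro in place of nitro on an aromatic carbon, ortho to a large group.

For the measured compounds named here, two measured steps bear on this change. Nitro in place of fluoro on an aromatic carbon gave a 1.3-fold lower number from compound 1 to compound 2 (0.10 log units; within the scatter). Replacing 2-fluorophenyl with 4-methylphenyl gave a 1.1-fold higher number from compound 1 to compound 3 (0.04 log units; within the scatter). Both steps stay within the scatter, although neither involves chloro, and three compounds are thin evidence. No step beyond the scatter is therefore expected in this assay. The expected change is a 1.2-fold higher number from compound 2 to compound 4 (0.07 log units; within the scatter). For compound 4, the estimated value is 38000 nM, with an expected range of 20000 nM to 70000 nM.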

Compound 4, half-maximal inhibitory concentration: 36800 nM
The estimate for compound 4 lay 1.0-fold (0.01 log units) above the measured number, and the stated range covers the measured number.
By their numbers in this assay, from the lowest: compounds 2, 4, 1 and 3 (each within the scatter of the next).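

In this assay, the nitro, with its three heavy atoms and two hydrogen-bond acceptors, gives way to a chloro, a single heavy atom with no acceptors, in a step of a 1.1-fold higher number from compound 2 to compound 4 (0.05 log units; within the scatter), and exchanging fluoro for chloro at the same aromatic carbon gives a 1.1-fold lower number from compound 1 to compound 4 (0.05 log units; within the scatter), so fluoro, nitro and chloro, all ortho to a large group, now cannot be told apart in this read-out. The comparison with the differently substituted ring adds a 1.2-fold lower number from compound 3 to compound 4 (0.09 log units; within the scatter), which places 2-chlorophenyl alongside 4-methylphenyl and leaves all four compounds as one flat group, with none standing apart. No measurement here offers an explanation for this flatness.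

As far as these compounds go, all the groups compared so far on this ring are small and carry no charge, so it remains open whether an amine or a carboxylic acid on the same aromatic carbon would produce a step beyond the scatter. From the compounds shown here alone, it is also open whether a longer chain in place of the saturated chain carbon bound to the sulfur, or any change to the shared core, would move these numbers at all.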